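A Chloro for a Methyl on the Benzyl Arm

The source may report more compounds than this note shows. Statements on the series, on what has been measured and on what is new or still open speak of the compounds shown alone.

Compound 3 `Cc1ccc(CNc2ncc(C(=O)O)c3nc(-c4ccco4)nn23)cc1`, which carries a 4-methylbenzyl group on a nitrogen of the shared core, gives 751 nM in an assay on CHO cells for displacement of a labelled ligand from adenosine receptor A3 (Homo sapiens); on this read-out higher numbers stand for weaker inhibition and lower numbers for stronger inhibition. Among the three compounds measured so far, this is the second highest number. Compound 2 `CCNc1ncc(C(=O)O)c2nc(-c3ccco3)nn12`, with an ethyl group in the same place, gives 480 nM, and the step of a 1.6-fold higher number from compound 2 to compound 3 (0.19 log units; within the scatter) lies within the usual scatter, so the two cannot be ranked. Compound 1 `CNc1ncc(C(=O)O)c2nc(-c3ccco3)nn12`, with only a methyl group there, gives 15900 nM; the steps of a 33-fold lower number from compound 1 to compound 2 (1.52 log units; beyond the scatter) and a 21-fold lower number from compound 1 to compound 3 (1.33 log units; beyond the scatter) show how strongly either larger group lowers the number.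

Compound 4 `O=C(O)c1cnc(NCc2ccc(Cl)cc2)n2nc(-c3ccco3)nc12` differs from compound 3 by chloro in place of methyl on an aromatic carbon. Among the compounds with values here, none of the measured steps touches a group on that phenyl ring: the two large steps concern what hangs from the chain carbon bound to the ring nitrogen, and the one step that swaps methyl for 4-methylphenyl there stays within the scatter. With nothing measured that tests a change on the phenyl ring itself, the expectation is a step no larger than the scatter, in either direction. Compound 4 is therefore expected to give about 650 nM, within 250 nM to 1800 nM, which would mean a 1.2-fold lower number from compound 3 to compound 4 (0.06 log units; within the scatter).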

Compound 4, inhibition constant: 11600 nM
Beside the measured number, compound 4's estimate is 18-fold (1.25 log units) below it; measured number above the stated range.
By their numbers in this assay, from the lowest: compounds 2 and 3 (each within the scatter of the next); then compounds 4 and 1 (each within the scatter of the next).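

Chloro and methyl each count as one heavy atom, yet on an aromatic carbon para to a large group this exchange gives a 15-fold higher number from compound 3 to compound 4 (1.19 log units; beyond the scatter) in this assay, so this place on the phenyl ring clearly matters, which no earlier step could show. It also qualifies the earlier picture, in which a larger group on the chain carbon lowered the number: 4-chlorophenyl gives a 24-fold higher number from compound 2 to compound 4 (1.38 log units; beyond the scatter) when set against methyl at that carbon, and against hydrogen it gives only a 1.4-fold lower number from compound 1 to compound 4 (0.14 log units; within the scatter), so compound 4 loses the advantage that compound 3 showed over compound 1. No measurement at hand explains why a single-atom exchange has so large an effect.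

With only methyl and chloro at this place, the compounds shown cannot tell which of the two is the unusual one, and a plain benzyl, a fluoro, a methoxy or an amine there would help to settle it. Also open, on these data alone, is whether the same exchange would have so large an effect if the carboxylic acid on the shared core were replaced by a methyl ester or an amide.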